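Aryl amide swap on a shared core: paw edema inhibition

The source may report more compounds than this note shows. Statements on the series, on what has been measured and on what is new or still open speak of the compounds shown alone.

Measured compounds:
- compound 1 `O=C(Nc1ccccn1)c1c(O)c2cccnc2n(-c2ccccc2)c1=O`: -13.5%
- compound 2 `CCCCNC(=O)c1c(O)c2cccnc2n(-c2ccccc2)c1=O`: 12.8%
- compound 3 `O=C(Nc1cccc([N+](=O)[O-])c1)c1c(O)c2cccnc2n(-c2ccccc2)c1=O`: 5.7%

The three compounds share one core and differ only in the group on the amide-type nitrogen. In a functional assay on the whole organism for inhibition, with Rattus norvegicus as the target, read by paw edema, at a dose of 100 mg/kg by the oral route (on this read-out lower numbers stand for less inhibition and higher numbers for more inhibition at the one dose given (going by the name of the read-out)), compound 1 gives -13.5%, compound 2 gives 12.8% and compound 3 gives 5.7%. Compound 3 stands second highest of the three; its gap to compound 2 is within the scatter, while a number 19.2 percentage points higher from compound 1 to compound 3 (beyond the scatter) is beyond it. Compound 4 `COc1ccccc1NC(=O)c1c(O)c2cccnc2n(-c2ccccc2)c1=O` is not yet measured. It differs from compound 3 in one place: 2-methoxyphenyl in place of 3-nitrophenyl on an amide-type nitrogen.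

Within the data shown here, none of the measured steps exchanges one substituted phenyl for another, so no step bears directly on this change. The two steps that exist, a number 26.3 percentage points higher from compound 1 to compound 2 (beyond the scatter) and a number 19.2 percentage points higher from compound 1 to compound 3 (beyond the scatter), both start from the pyridin-2-yl amide, and a number 7.1 percentage points lower from compound 2 to compound 3 (within the scatter) lies within the scatter. With nothing pointing in either direction, the expected step of a number 0.7 percentage points lower from compound 3 to compound 4 (within the scatter) is none beyond the scatter. Compound 4 is therefore estimated at 5%, within a range from -15% to 22%.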

Compound 4, a percentage reported as inhibition, in the whole organism at one dose (the size of the read-out at that dose, not a potency): 8.1%
Compound 4: the middle estimate sits 3.1 percentage points below what was measured; low and high end bracket the measured number.
By their numbers in this assay, from the lowest: compound 1; then compounds 3, 4 and 2 (each within the scatter of the next).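

In this assay the exchange of 3-nitrophenyl for 2-methoxyphenyl, the first between two substituted phenyl groups, gives a number 2.4 percentage points higher from compound 3 to compound 4 (within the scatter) and does not separate the two groups on this amide-type nitrogen. Putting 2-methoxyphenyl in place of butyl gives a number 4.7 percentage points lower from compound 2 to compound 4 (within the scatter) and again separates nothing, while putting it in place of pyridin-2-yl gives a number 21.6 percentage points higher from compound 1 to compound 4 (beyond the scatter) and leaves compound 1 as the only one standing apart from the rest. No measurement shown offers a reason for any of these numbers.

Still open, on these data alone, is whether an amine or a carboxylic acid on the phenyl ring, or a longer chain in place of butyl, would move the number beyond the scatter. Also open is how 3-methoxyphenyl or 2-nitrophenyl would compare with the two substituted phenyl groups shown.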